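Compound 3: cyclohexyl in place of cyclopentyl

A few compounds are considered here, and "the series" means these few. Any claim that something is new, unique, unknown or untested is made for them only; others in the source may bear on it.

Within the data shown here, in a physicochemical assay for solubility, measured as thermodynamic solubility, at pH 7.4 (on this read-out lower numbers stand for lower solubility and higher numbers for higher solubility), compound 1 `O=C1CCOc2nc(C#Cc3ccccc3)ccc21` gives 23000 nM and compound 2 `O=C1CCOc2nc(C#CC3CCCC3)ccc21` gives 23000 nM, which leaves compound 2 level with compound 1 at the digits available, with no other measured compound to place it against.

Compound 3 `O=C1CCOc2nc(C#CC3CCCCC3)ccc21` has not yet been measured. It carries cyclohexyl in place of cyclopentyl on a triple-bonded carbon.

Among the measured compounds shown here, only one measured step bears on this change. It sits at the same place, with cyclopentyl in place of phenyl, and it is no change at the digits printed from compound 1 to compound 2 (within the scatter) in size. For the measured compounds named here, that is a single precedent, and no measurement yet compares a five-membered with a six-membered ring of carbon only, so the support is thin. On that basis no step beyond the scatter is expected in this assay for this change, in either direction. The estimated 1.2-fold lower number from compound 2 to compound 3 (0.06 log units; within the scatter) therefore stays inside the scatter.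

Compound 3 is estimated at 20000 nM (expected range 10000 nM to 40000 nM).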

Compound 3, solubility: 57000 nM
Estimate against measurement, compound 3: 2.9-fold (0.45 log units) below; the measured number lies above the stated range.
By their numbers in this assay, from the lowest: compounds 1 and 2 (each within the scatter of the next); then compound 3.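

In this assay the place on a triple-bonded carbon now proves able to shift the read-out, as cyclohexyl in place of cyclopentyl gives a 2.5-fold higher number from compound 2 to compound 3 (0.39 log units; beyond the scatter) while the earlier exchange at this place gave no change at the digits printed from compound 1 to compound 2 (within the scatter) without any step beyond the scatter. Cyclohexyl in place of phenyl gives a 2.5-fold higher number from compound 1 to compound 3 (0.39 log units; beyond the scatter) and so puts compound 3 apart from both earlier compounds, whereas the phenyl of compound 1 and the cyclopentyl of compound 2 stay level at the digits printed, so a five-membered and a six-membered ring of carbon only need not behave alike here. No measurement at hand accounts for this step, which for now stands as a single observation on the shared core.

Three compounds cannot show whether the rise continues with a larger ring of carbon only, such as cycloheptyl, or belongs to cyclohexyl alone. On these data alone, the effect of a ring or chain bearing a heteroatom at this place also remains open, for example a piperidine with its amine, a tetrahydropyran with its ether oxygen, or a longer open chain such as hexyl.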